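The source may hold more compounds than are shown below. What is called first, only, known or untested is meant among the compounds shown, and "the series" means these compounds.

Among the compounds with values here, compound 2 `C=CCn1nc(C(=O)NCc2ccccc2)cc1-c1sc(NC(=O)C(C)(C)C)nc1C` holds the highest of the two numbers so far in an in vitro assay on FRT cells for binding affinity to Cystic fibrosis transmembrane conductance regulator (Homo sapiens), read by fluorescence, with a stated time of 20 h (a higher number here means that more compound is needed for the effect, a lower number that less compound is needed), where compound 2 gives 3000 nM. Its nearest neighbour, compound 1 `C=CCn1nc(C(=O)Nc2ccc(OC)cc2)cc1-c1sc(NC(=O)C(C)(C)C)nc1C`, gives 930 nM, and the step of a 3.2-fold higher number from compound 1 to compound 2 (0.51 log units; beyond the scatter) arose from swapping the group on the amide-type nitrogen. Compound 3 `Cc1nc(NC(=O)C(C)(C)C)sc1-c1cc(C(=O)NCc2ccccc2)nn1Cc1ccccc1` changes a different place: phenyl in place of vinyl on a saturated chain carbon bound to an aromatic nitrogen. Within the data shown here, no measured step touches this position, so nothing indicates a direction. The step from compound 2 to compound 3 is therefore expected to stay within the scatter, no change at the digits printed from compound 2 to compound 3 (within the scatter). Compound 3 is estimated at 3000 nM, with a range from 1000 nM to 9000 nM.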

Compound 3, half-maximal effective concentration in the Cystic fibrosis transmembrane conductance regulator assay: 750 nM
Compound 3: middle estimate off by 4.0-fold (0.60 log units), on the high side; the whole stated range lies above it.
By their numbers in the Cystic fibrosis transmembrane conductance regulator assay, from the lowest: compounds 3 and 1 (each within the scatter of the next); then compound 2.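

Swapping vinyl for phenyl on a saturated chain carbon bound to an aromatic nitrogen gives, in the Cystic fibrosis transmembrane conductance regulator assay, a 4.0-fold lower number from compound 2 to compound 3 (0.60 log units; beyond the scatter). This position, like the amide-type nitrogen, can therefore move the number beyond the scatter, and the larger group with its aromatic ring is the better of the two here. In a physicochemical assay for lipophilicity, read by HPLC, measured as octanol-water partition (on this read-out lower numbers stand for lower lipophilicity and higher numbers for higher lipophilicity), compound 2 gives 4.53 and compound 3 gives 5.09. Lipophilicity rises with the same change, although a single pair cannot show whether this explains the lower number: the measured partition coefficient of compound 2, 4.53, and of compound 3, 5.09, a number 0.56 log units higher (beyond the scatter)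

Going by these compounds, it remains open whether the aromatic ring itself matters, which a cyclohexyl or pyridyl group in place of the phenyl could test. On these data alone, it also remains open how benzyl at this position would combine with 4-methoxyphenyl on the amide-type nitrogen.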